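The source may hold more compounds than are shown below. What is called first, only, known or untested is meant among the compounds shown, and "the series" means these compounds.

Compound 1, `Fc1cc(F)c2ncc(-c3nn[nH]n3)cc2c1`: 10 mg/kg
Compound 2, `Fc1cccc2cc(-c3nn[nH]n3)cnc12`: > 10 mg/kg
Compound 3, `O=C(O)c1cnc2c(F)cccc2c1`: > 25 mg/kg

In a functional assay on the whole organism (strain Sprague-Dawley) for inhibition, with Rattus norvegicus as the target (a lower number here means that less compound is needed, a higher number that more compound is needed for the effect), compound 1 gives 10 mg/kg. For compound 2 the assay reports only a limit, > 10 mg/kg. For compound 3 the assay likewise reports only a limit, > 25 mg/kg. Compound 2 thus stands at a limit rather than at a number, and one further value among the three shown is also a limit. The change to compound 4, `Cc1cccc2cc(-c3nn[nH]n3)cnc12`, is methyl in place of fluoro on an aromatic carbon. The measured steps that touch compound 2 are a number no lower from compound 1 to compound 2 (the limit leaves the size open) and a step that the two limits leave unreadable from compound 2 to compound 3; neither has a readable size, so no direction beyond the scatter is expected for the new step. Compound 4 is therefore expected to give 20 mg/kg, estimated between 8 mg/kg and 60 mg/kg, which would mean a step that the limit leaves unreadable from compound 2 to compound 4.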

Compound 4, minimum effective dose: < 25 mg/kg
Compound 4: no number, only a limit (the forecaster's own chance of this, stated with the estimate: 60%); the middle value lies beyond the limit too.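

In this assay compound 2 gives only a limit, > 10 mg/kg. Compound 4 also gives only a limit, < 25 mg/kg. The step between compound 2 and compound 4 therefore cannot be read. The compounds shown leave open whether methyl or fluoro on this aromatic carbon calls for less compound.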